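Removing the formyl group from compound 2

The compounds below may be only part of what the source reports. "The series", "measured", "known", "first", "only" and "open" are said of these compounds alone.

Measured in a functional assay on HepG2 cells (Homo sapiens) for antiproliferative activity, read by MTT assay, with a stated time of 24 h; on this read-out lower numbers stand for stronger inhibition and higher numbers for weaker inhibition:
- compound 1 `C=CCc1cc(-c2cccc([N+](=O)[O-])c2)ccc1O` gives > 100000 nM as a limit of the assay
- compound 2 `C=CCc1cc(C=O)c(OCC)c(-c2ccc(OCC)c(CC=C)c2)c1` gives 28500 nM as a number
- compound 3 `C=CCc1ccc(OC(C)C)c(-c2ccc(OC(C)C)c(CC=C)c2)c1` gives > 114000 nM as a limit of the assay

For the measured compounds named here, compound 2 stands alone here as the only compound with an actual number, at 28500 nM in this series. Going to compound 4 `C=CCc1ccc(OCC)c(-c2ccc(OCC)c(CC=C)c2)c1`, hydrogen takes the place of formyl on an aromatic carbon hydrogen in place of formyl on an aromatic carbon and the rest of the structure stays the same. Going by the values given here, no measured pair isolates this change in this assay. Compound 3 also lacks formyl and gives > 114000 nM as a limit. A weakening beyond the scatter is therefore expected, meaning a higher number, and the expected 2.5-fold higher number from compound 2 to compound 4 (0.39 log units; beyond the scatter) is moderate. Compound 4 is estimated at 70000 nM with an expected range from 30000 nM to 160000 nM as its bounds.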

Compound 4, half-maximal inhibitory concentration: > 124000 nM
Compound 4 ended at the assay's limit (the forecaster's own chance of this, stated with the estimate: 45%); middle value at least 1.7-fold (0.24 log units) from the limit.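

In this assay, for the compounds shown here, hydrogen in place of formyl on the aromatic carbon ortho to an ethoxy group gives an at least 4.3-fold higher number from compound 2 to compound 4 (0.63 log units; beyond the scatter), the first one-place reading at this position. The loss lies beyond the scatter, and compound 4 sits at a limit of the assay, so its full size stays unknown: the limit of > 124000 nM in this assay, at which 1 of the 4 values shown sits.

Among the compounds shown, formyl appears only in compound 2, the only one with an actual number. From the compounds shown here alone, whether formyl itself is needed stays open; a hydroxymethyl, a carboxylic acid or an amine on this carbon would test that.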